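Homologating a Hydroxy Group on a Saturated Ring Chain

The source may report more compounds than this note shows. Statements on the series, on what has been measured and on what is new or still open speak of the compounds shown alone.

This account follows three measured compounds and one that awaits measurement. Compound 1 `C=CCc1ccc(OCc2cn(-c3ccccc3CO)nn2)c(O)c1`, compound 2 `C=CCc1cc(O)c(O)c(CN2CCC(CO)CC2)c1` and compound 3 `C#CCOc1ccc(CC=C)cc1O` were all tested in a functional assay on MIA PaCa-2 cells (Homo sapiens) for inhibition, read by MTT assay, with a stated time of 72 h, tested at 30 uM; a lower number here means less inhibition of growth, a higher number more inhibition of growth at the concentration tested. In this assay compound 1 gives 39.6%, compound 2 gives 34.1% and compound 3 gives 27.4%. The three numbers lie close together: the value of compound 2 differs from that of compound 1 and from that of compound 3 by amounts that stay within the usual scatter of such measurements, so no order among them can be read.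

Compound 4 `C=CCc1cc(O)c(O)c(CN2CCC(CCO)CC2)c1` has not yet been measured. It differs from compound 2 in one place: hydroxymethyl in place of hydroxy on a saturated chain carbon bound to a saturated ring carbon. For the measured compounds named here, no measured pair shows a step of this kind, so there is nothing to draw on for its size or direction. Given that even the larger differences among compounds 1, 2 and 3 remain within the scatter, the step from compound 2 to compound 4 is expected to be small, with no direction beyond the scatter, as a number 0.1 percentage points lower from compound 2 to compound 4 (within the scatter). Compound 4 is therefore estimated to give 34% in this assay, within a range from 24% to 45%.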

Compound 4, percent growth inhibition at one concentration: 54.4%
The estimate for compound 4 lay 20.4 percentage points below the measured number, and the stated range ends below it.
By their numbers in this assay, from the lowest: compounds 3, 2 and 1 (each within the scatter of the next, the first and the last beyond it); then compound 4.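

In this assay, for the compounds shown here, the change from hydroxymethyl to 2-hydroxyethyl on the saturated ring gives the first step here that stands beyond the scatter: a number 20.3 percentage points higher from compound 2 to compound 4 (beyond the scatter). This place therefore responds to a small change, with one carbon added while the counts of hydrogen-bond donors and acceptors stay the same and no net charge enters. Nothing available accounts for the size of this step.

This single step does not show whether a longer chain ending in hydroxy would extend the trend or reverse it. It also leaves open whether the hydroxy itself is needed, a question that an amine or a carboxylic acid in its place would address.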